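This account rests on a few compounds, and the source may have more. Where it says the series, first, only, none or still open, it means among the compounds named here.

Compound 1, `Cn1nc2c(=O)n(CC3(O)CCN(Cc4ccc(-c5ccco5)cc4Cl)CC3)cnc2c1-c1ccc(CNS(C)(=O)=O)cc1`, is the starting point here. In an assay on isolated protein for inhibition of ubiquitin carboxyl-terminal hydrolase 7 (Homo sapiens), with stated times of 30 min and 2 h (on this read-out higher numbers stand for weaker inhibition and lower numbers for stronger inhibition), compound 1 gives 65.3 nM. Two close relatives were measured alongside it. Compound 2, `Cn1nc2c(=O)n(CC3(O)CCN(Cc4ccc(-c5ccncc5)cc4Cl)CC3)cnc2c1-c1ccc(CN)cc1`, gives 257 nM, and compound 3, `Cn1nc2c(=O)n(CC3(O)CCN(Cc4ccc(-c5cncs5)cc4Cl)CC3)cnc2c1-c1ccc(CN)cc1`, gives 117 nM. Among the measured compounds shown here, the one measured step between compounds that differ in a single place is a 2.2-fold lower number from compound 2 to compound 3 (0.34 log units; beyond the scatter), a change on an aromatic carbon far from the benzylic amine. Among these three numbers compound 1 has the lowest; the nearest is compound 3, within the usual scatter, and the furthest is compound 2, beyond it.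

The unmeasured compound 4, `CCCNCc1ccc(-c2c3ncn(CC4(O)CCN(Cc5ccc(-c6ccco6)cc5Cl)CC4)c(=O)c3nn2C)cc1`, differs from compound 1 at the benzylic amine nitrogen: propyl in place of methylsulfonyl on an amine nitrogen. For the measured compounds named here, no measured step touches this position. The step from compound 2 to compound 3 concerns a different ring and so says nothing about exchanging a methylsulfonyl for a propyl on an amine nitrogen. Compounds 1 and 2 differ both at this nitrogen and on the aromatic carbon, so their values cannot be separated into one cause. Going by the values given here, with no guiding step, the change is expected to fall close to the scatter, with a 1.4-fold higher number from compound 1 to compound 4 (0.14 log units; within the scatter) as the expected size. For compound 4 the estimated value is 90 nM, expected to lie between 30 nM and 270 nM.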

Compound 4, half-maximal inhibitory concentration: 43.9 nM
For compound 4 the middle estimate is 2.1-fold (0.31 log units) above the measured one, within the range that was stated.
By their numbers in this assay, from the lowest: compounds 4, 1 and 3 (each within the scatter of the next, the first and the last beyond it); then compound 2.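

In this assay, putting propyl in place of methylsulfonyl on the amine nitrogen gives a 1.5-fold lower number from compound 1 to compound 4 (0.17 log units; within the scatter), so this single exchange leaves the number within the usual scatter. Among the compounds shown here, this is the first direct reading at this nitrogen, and it shows that two quite different substituents give values that cannot be told apart here: methylsulfonyl, with its sulfur, two oxygens and two hydrogen-bond acceptors, and propyl, a plain three-carbon chain with no acceptors. The measurements offer no explanation for why these two groups read alike.

This one pair leaves open whether other groups on the same nitrogen would also stay within the scatter, for instance a longer chain such as butyl, an acetyl group or a chain ending in a carboxylic acid. Also open, from the compounds shown here alone, is how the bare primary amine, carried by compound 2 and compound 3, would read on the otherwise unchanged structure of compound 1, since those two compounds differ from compound 1 in more than one place.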